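Swapping cyclopropyl for methyl on a sulfonyl sulfur

The source may report more compounds than this note shows. Statements on the series, on what has been measured and on what is new or still open speak of the compounds shown alone.

Compound 1 `CC(C)COc1ncc(-c2cn(C)c3cc(C(=O)NS(=O)(=O)C4CC4)c(F)cc23)cc1Cl`: 100%
Compound 2 `Cn1cc(-c2ccc(C(F)(F)F)cc2)c2ccc(C(=O)NS(=O)(=O)C3CC3)cc21`: 87%

The measure here is an ADME assay on microsomes from liver (Mus musculus) for metabolic stability, with a stated time of 10 min, tested at 0.5 uM; a higher number here means that more of the compound is left, a lower number that less of the compound is left. Compound 1 stands highest of the two measured compounds at 100%. Compound 2 comes next with 87%, and that gap lies beyond the usual scatter of repeated measurements.

The next compound to be tested is compound 3 `CC(C)COc1ncc(-c2cn(C)c3cc(C(=O)NS(C)(=O)=O)c(F)cc23)cc1Cl`. It keeps the core of compound 1 and changes one group: methyl in place of cyclopropyl on a sulfonyl sulfur. In words, methyl takes the place of cyclopropyl on a sulfonyl sulfur.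

Both measured compounds carry the cyclopropylsulfonyl group, and they differ from each other in several places. The data therefore hold no direct measurement of this swap, and any forecast is uncertain. The starting point is compound 1 at 100%, which leaves little room for a rise in this assay. A modest fall or no change beyond the scatter is expected, and the estimated step is a number 6 percentage points lower from compound 1 to compound 3 (within the scatter). For compound 3 the expected value is 94%, with an estimated range of 80% to 100%.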

Compound 3, percent of the compound remaining: 100%
For compound 3 the middle estimate is 6 percentage points below the measured one; the range from low to high includes it.
By their numbers in this assay, from the lowest: compound 2; then compounds 1 and 3 (each within the scatter of the next).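

Methyl in place of cyclopropyl on a sulfonyl sulfur gives no change at the digits printed from compound 1 to compound 3 (within the scatter) in this assay. For the compounds shown here, this is the first direct reading of this change, since both earlier compounds carry the cyclopropylsulfonyl group and differ from each other in several other places. With the rest of compound 1 held fixed, the three-membered ring is not needed for the compound to remain in this test, and the smaller methylsulfonyl group serves equally well, although nothing at hand explains the result.

Compound 1 and compound 3 both sit at the top of what this read-out can show, so any difference between the two groups that would appear only under harsher conditions stays hidden here. Going by these compounds, it also remains open whether a longer chain such as ethyl or propyl, or an amine such as dimethylamino, would fare the same on this sulfonyl sulfur, and whether the swap from cyclopropyl to methyl would read the same on the different structure of compound 2.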